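The source may report more compounds than this note shows. Statements on the series, on what has been measured and on what is new or still open speak of the compounds shown alone.

Measured compounds:
- compound 1, `Nc1nn(C(=O)Nc2ccc(Cc3ccccc3)cc2)c2ccccc12`: "not determined" (no result reported)
- compound 2, `Nc1nn(C(=O)Nc2ccc(Cc3ccccc3)cc2)c2ccc(Cl)cc12`: 1230 nM

Among the compounds with values here, compound 2 is the only member of the series with a number in a functional assay on CCRF-CEM cells (Homo sapiens) for antiproliferative activity, read by sulforhodamine B assay, with a stated time of 48 h; a higher number here means a weaker inhibitor of growth, a lower number a stronger inhibitor of growth; compound 1 carries no result there, so compound 2 cannot be placed relative to anything else. In this assay compound 2 gives 1230 nM.

Compound 3, `Nc1ccc2c(c1)c(N)nn2C(=O)Nc1ccc(Cc2ccccc2)cc1`, differs from compound 2 in one place: amino in place of chloro on an aromatic carbon, on a six-membered aromatic carbon ring of the fused two-ring system, meta to a fused ring and para to a fused ring. Within the data shown here, no measured pair shows this exchange, so the size of the step is not given by the data. The replacement of a halogen by a group that brings one hydrogen-bond donor and one acceptor is taken as likely to cost some potency, though a shift within the scatter is also plausible. The expected step is a 1.8-fold higher number from compound 2 to compound 3 (0.25 log units; within the scatter), estimated as modestly weakening. Compound 3 is estimated at 2200 nM, with a range of 700 nM to 7000 nM.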

Compound 3, concentration for 50% growth inhibition: 2070 nM
Beside the measured number, compound 3's estimate is 1.1-fold (0.03 log units) above it, and the stated range covers the measured number.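

In this assay, the exchange of chloro for amino on the aromatic carbon, meta to a fused ring and para to a fused ring, gives a 1.7-fold higher number from compound 2 to compound 3 (0.23 log units; within the scatter) and so leaves the growth inhibition unchanged within the scatter. Within the data shown here, this is the first readable step, and it shows that at this position the potency does not depend on which of these two single-atom groups is present. Nothing measured here bears on a reason for this result.

Among these compounds, compound 1 has no number, so no step to the compound without a group at this position can be read. From the compounds shown here alone, a second halogen such as bromine, a methoxy group, a carboxylic acid or a longer chain at this carbon could show whether the position stays this permissive, and changes elsewhere on the shared core remain open too.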